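The source may report more compounds than this note shows. Statements on the series, on what has been measured and on what is new or still open speak of the compounds shown alone.

Measured compounds:
Compound 1 `N#CC1=C(NCC(=O)N2CCOCC2)N(c2ccccc2)C(=O)N2CCCCC(N3CCCC3)C12` — in a functional assay on the whole organism (strain albino) for inhibition, with Rattus norvegicus as the target, read by paw edema, with stated times of 1 h and 3 h, at a dose of 20 mmol/kg by the intraperitoneal route (a lower number here means a weaker effect, a higher number a stronger effect of the compound at the dose given), compound 1 gives 73.5%.
Compound 2 `N#CC1=C(NCC(=O)N2CCCC2)N(c2ccccc2)C(=O)N2CCCCC(N3CCCC3)C12` — in this assay compound 2 gives 56%.
Compound 3 `N#Cc1c2n(c(=O)n(-c3ccccc3)c1=N)CCCCC2N1CCCC1` — in this assay compound 3 gives 93.4%.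

Among these three, compound 2 stands lowest. Among the measured compounds shown here, its nearest neighbour is compound 1, and the only step that is documented between two measured compounds runs between them: a number 17.5 percentage points lower from compound 1 to compound 2 (beyond the scatter). Compound 3, which carries no side chain of this kind at all, lies furthest above it.

Compound 4 `CCOC(=O)C(=O)NC1=C(C#N)C2C(N3CCCC3)CCCCN2C(=O)N1c1ccccc1` has not yet been measured. It differs from compound 2 in a single region: (ethoxycarbonyl)carbonyl in place of ((pyrrolidin-1-yl)carbonyl)methyl on an amine nitrogen. For the measured compounds named here, the step from compound 1 to compound 2 also alters the group attached to the carbonyl in this side chain, so it is the one measurement that bears on the change, but it does not reproduce it, since in compound 4 the whole ((pyrrolidin-1-yl)carbonyl)methyl group is exchanged rather than only its ring. Going by the values given here, no measured pair shows what the (ethoxycarbonyl)carbonyl group does here. The observer therefore expects no step beyond the scatter and places compound 4 near compound 2, with a wide allowance: a number 4 percentage points higher from compound 2 to compound 4 (within the scatter). Compound 4 is estimated at 60%, with a range from 35% to 85%.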

Compound 4, a percentage reported as inhibition, in the whole organism at one dose (the size of the read-out at that dose, not a potency): 91.5%
Compound 4: the middle estimate sits 31.5 percentage points below what was measured; measured number outside the range, above it.
By their numbers in this assay, from the lowest: compound 2; then compound 1; then compounds 4 and 3 (each within the scatter of the next).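

In this assay, the amine nitrogen proves a far more sensitive place for change than the earlier exchange of one ring for another had shown: replacing the whole ((pyrrolidin-1-yl)carbonyl)methyl group with (ethoxycarbonyl)carbonyl gives a number 35.5 percentage points higher from compound 2 to compound 4 (beyond the scatter) and is the only step here printed as large. The morpholine-bearing side chain also falls short of the new group, with a number 18 percentage points higher from compound 1 to compound 4 (beyond the scatter) in the same direction, so both ((ring)carbonyl)methyl chains measured here lie below the (ethoxycarbonyl)carbonyl group, whereas the earlier a number 17.5 percentage points lower from compound 1 to compound 2 (beyond the scatter) had shown only that the ring on the carbonyl matters within that one chain type. Nothing available here offers an explanation for this rise.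

The compounds shown cannot tell whether the gain follows from the ethyl ester, from the carbonyl placed directly on the amine nitrogen, or from the loss of the ring, since that exchange alters all of these at once. A carboxylic acid or a methyl ester in place of the ethyl ester, or a pyrrolidine amide on the same two-carbonyl chain, would separate these parts, and each reading here still rests on a single dose.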